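This account rests on a few compounds, and the source may have more. Where it says the series, first, only, none or still open, it means among the compounds named here.

Of the compounds shown here, two built on one shared core have been tested in a functional assay on HeLa cells (Homo sapiens) for antiproliferative activity, read by MTT assay, with a stated time of 48 h, in the presence of a further agent that is not named here; a higher number here means a weaker inhibitor of growth, a lower number a stronger inhibitor of growth. Compound 1 `COc1ccc(-c2nn(-c3ccccc3)cc2C(=O)NOCc2ccccc2F)cc1` gives 2900 nM. Compound 2 `COc1ccc(-c2nn(-c3ccccc3)cc2C(=O)NOCc2ccc(Cl)cc2Cl)cc1` gives 5750 nM. Among the compounds with values here, the one change between them, a 2.0-fold higher number from compound 1 to compound 2 (0.30 log units; within the scatter), sits on the saturated chain carbon bound to an oxygen, where a 2,4-dichlorophenyl replaces a 2-fluorophenyl. Of the two numbers, compound 2 holds the higher one, and its nearest neighbour is compound 1, but that gap lies within the scatter of this assay, so neither compound can be called the stronger or weaker inhibitor of growth on this evidence.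

Compound 3 `O=C(NOCc1ccc(Cl)cc1Cl)c1cn(-c2ccccc2)nc1-c1ccc(F)cc1` differs from compound 2 elsewhere in the molecule: fluoro in place of methoxy on an aromatic carbon, on a six-membered aromatic ring of carbon only, para to a large group. Within the data shown here, no measured step touches this position, and the single recorded step concerns a different part of the core, so there is nothing here to point to a rise or a fall. The expectation is therefore a step of a 1.0-fold higher number from compound 2 to compound 3 (0.02 log units; within the scatter), that is, no change beyond the scatter, with wide uncertainty. Compound 3 is expected to give about 6000 nM, in the range 2000 nM to 18000 nM.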

Compound 3, concentration for 50% growth inhibition: 7350 nM
Beside the measured number, compound 3's estimate is 1.2-fold (0.09 log units) below it, and the stated range covers the measured number.
By their numbers in this assay, from the lowest: compounds 1, 2 and 3 (each within the scatter of the next, the first and the last beyond it).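

In this assay, the change from 4-methoxyphenyl to 4-fluorophenyl reads as a 1.3-fold higher number from compound 2 to compound 3 (0.11 log units; within the scatter) with the 2,4-dichlorophenyl group held fixed, and this is the only measured change at this position among the compounds shown. Methoxy brings two heavy atoms and a hydrogen-bond acceptor, whereas fluoro brings one heavy atom and no acceptor, yet this assay does not separate compound 2 from compound 3, so this particular swap on the aromatic carbon, para to a large group, gives no sign of mattering for growth inhibition in HeLa cells. Nothing measured here bears on why the two compounds read alike.

A single pair cannot show whether the position tolerates every group, and an amine, a carboxylic acid or a longer chain such as butoxy in the same place could read quite differently. As far as these compounds go, it also remains open whether the same swap would read the same way with the 2-fluorophenyl group of compound 1 in place of the 2,4-dichlorophenyl group.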